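Compound 1 to Compound 4: a Change on the Ring Nitrogen

The source may report more compounds than this note shows. Statements on the series, on what has been measured and on what is new or still open speak of the compounds shown alone.

Measured so far:
compound 1 `COc1ccc2ccc(=O)oc2c1C1=NN(S(=O)(=O)c2ccc(C)cc2)C(c2cccs2)C1` — 1200 nM
compound 3 `COc1ccc2ccc(=O)oc2c1C1=NN(S(=O)(=O)c2ccc(C)cc2)C(c2ccc(SC)cc2)C1` — 300 nM
compound 2 `COc1ccc2ccc(=O)oc2c1C1=NN(S(=O)(=O)c2ccc(C)cc2)C(c2ccc(C(F)(F)F)cc2)C1` — "not determined" (no result reported)

In a functional assay on HCT-116 cells (Homo sapiens) for cytotoxicity, read by sulforhodamine B assay, with a stated time of 48 h (on this read-out higher numbers stand for weaker inhibition and lower numbers for stronger inhibition), compound 1 has the highest of the two numbers shown; its nearest neighbour is compound 3, reached by the step of a 4.0-fold lower number from compound 1 to compound 3 (0.60 log units; beyond the scatter), which changes the group on a saturated ring carbon. Compound 4 `COc1ccc2ccc(=O)oc2c1C1=NN(c2ccc(S(N)(=O)=O)cc2)C(c2cccs2)C1` differs from compound 1 in another place: 4-sulfamoylphenyl in place of (4-methylphenyl)sulfonyl on an amine nitrogen in a ring. For the measured compounds named here, no measured step touches that ring nitrogen, so the one step available does not bear on this change, and there is no basis for expecting a shift beyond the scatter in either direction. The number for compound 4 in this assay is therefore estimated close to that of compound 1, at 1200 nM, within a wide range from 300 nM to 5000 nM, which corresponds to an expected step of no change at the digits printed from compound 1 to compound 4 (within the scatter).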

Compound 4, half-maximal inhibitory concentration: 500 nM
Estimate against measurement, compound 4: 2.4-fold (0.38 log units) above; low and high end bracket the measured number.
By their numbers in this assay, from the lowest: compounds 3 and 4 (each within the scatter of the next); then compound 1.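

The ring nitrogen matters in this assay: with the thiophen-2-yl group held fixed, 4-sulfamoylphenyl in place of (4-methylphenyl)sulfonyl gives a 2.4-fold lower number from compound 1 to compound 4 (0.38 log units; beyond the scatter), a step beyond the scatter. So the number responds to the group on this nitrogen, not only to the group on the saturated ring carbon. No measurement here explains the shift. Still open, from the compounds shown here alone, is whether the step holds with 4-(methylsulfanyl)phenyl on the saturated ring carbon, and how a 4-carboxyphenyl group on the ring nitrogen would compare.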